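Iodo in place of benzofuranyl on the ring carbon of compound 3

The source may hold more compounds than are shown below. What is called first, only, known or untested is meant among the compounds shown, and "the series" means these compounds.

Working notes on a set of ribosylated bicyclic nucleosides tested in a functional assay on HCT-116 cells (Homo sapiens), read by MTT assay, with a stated time of 72 h; a lower number here means a stronger inhibitor, a higher number a weaker inhibitor. Compound 1 `Nc1nc(N)c2c(-c3cc4ccccc4o3)cn([C@@H]3O[C@H](CO)[C@@H](O)[C@H]3O)c2n1` gives 14000 nM in this assay. Compound 3 `Cc1nc(N)c2c(-c3cc4ccccc4o3)cn([C@@H]3O[C@H](CO)[C@@H](O)[C@H]3O)c2n1` gives 13100 nM in this assay. Among the measured compounds shown here, the one single-point step measured so far, a 1.1-fold lower number from compound 1 to compound 3 (0.03 log units; within the scatter), is a methyl in place of amino on an aromatic carbon. Compound 2 `O=c1[nH]cnc2c1c(-c1ccsc1)cn2[C@@H]1O[C@H](CO)[C@@H](O)[C@H]1O` reaches only a limit in this assay, > 20000 nM. That limit is the one noted as the limit of > 20000 nM in this assay, at which 1 of the 3 values shown sits. Compound 3 therefore stands alongside compound 1 within the scatter, with the third value being a limit and not a number.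

Compound 4 `Cc1nc(N)c2c(I)cn([C@@H]3O[C@H](CO)[C@@H](O)[C@H]3O)c2n1` differs from compound 3 by iodo in place of 1-benzofuran-2-yl on an aromatic carbon. For the measured compounds named here, no measured step touches this carbon; the step from compound 1 to compound 3 concerns a different aromatic carbon, so it carries nothing over to this change, and compound 2 with its thiophenyl group offers only a limit. The expected step is therefore a 1.6-fold lower number from compound 3 to compound 4 (0.21 log units; within the scatter), set with a wide margin on both sides. Compound 4 is estimated at 8000 nM, with a range from 1000 nM to 40000 nM.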

Compound 4, half-maximal inhibitory concentration: > 20000 nM
Compound 4 gave a limit, no number; the forecaster's own chance of this, stated with the estimate: 25%; at least 2.5-fold (0.39 log units) between middle value and limit.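

In this assay compound 4 gives > 20000 nM, which is a limit of the assay and not a number. The step reads an at least 1.5-fold higher number from compound 3 to compound 4 (0.18 log units; that floor lies within the scatter), so at this carbon, two ring bonds from the ring nitrogen, iodo in place of 1-benzofuran-2-yl brings no gain, while the real size of any loss remains unresolved. The change also adds a second limit to the series: the limit of > 20000 nM in this assay, at which 2 of the 4 values shown sit.

The step has only a floor, so the compounds shown do not tell whether the fused aromatic group matters at this carbon or how far the number would rise without it. On these data alone, how a plain phenyl ring or an aminomethyl group would read here stays open, as does whether the amino and methyl pair, compound 1 and compound 3, would still match with iodo on this carbon.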